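Bromo-to-hydrogen step in a bis-enone series

The source may hold more compounds than are shown below. What is called first, only, known or untested is meant among the compounds shown, and "the series" means these compounds.

Measured so far in a functional assay on MDA-MB-231 cells (Homo sapiens) for cytotoxicity, read by MTT assay, with a stated time of 24 h; a lower number here means a stronger inhibitor, a higher number a weaker inhibitor:
compound 1 `Cc1cc(O)c(C(=O)/C=C/c2ccc(F)cc2)c(-c2ccc(Br)cc2)c1C(=O)/C=C/c1ccc(F)cc1`: 22300 nM
compound 2 `Cc1cc(O)c(C(=O)/C=C/c2ccc(Cl)cc2)c(-c2ccc(Cl)cc2)c1C(=O)/C=C/c1ccc(Cl)cc1`: 30000 nM

Compound 1 carries the lowest of the two numbers measured, but compound 2 sits within the scatter of it, so the two compounds are not distinguishable in this assay and neither can be called the stronger. The series has so far not shown any single-point change between measured compounds, so there is no step of known size to lean on.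

Compound 3 `Cc1cc(O)c(C(=O)/C=C/c2ccc(F)cc2)c(-c2ccccc2)c1C(=O)/C=C/c1ccc(F)cc1` is the next compound to go into this assay. It differs from compound 1 in one place: hydrogen in place of bromo on an aromatic carbon. Nothing measured here tells how a change of this kind moves the number in this assay. With compound 1 at 22300 nM and compound 2 at 30000 nM both lying in the same region, the working expectation is that compound 3 stays in that region as well, with the step of a 1.1-fold higher number from compound 1 to compound 3 (0.05 log units; within the scatter) expected to be no larger than the scatter. Compound 3 is therefore estimated at 25000 nM, within a range of 9000 nM to 70000 nM.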

Compound 3, half-maximal inhibitory concentration: 20000 nM
The estimate for compound 3 lay 1.3-fold (0.10 log units) above the measured number; the measured number falls inside the stated range.
By their numbers in this assay, from the lowest: compounds 3, 1 and 2 (each within the scatter of the next).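

Hydrogen in place of bromo on this aromatic carbon, para to a large group, gives the first single-place step in the series: in this assay the change from 4-bromophenyl to phenyl reads a 1.1-fold lower number from compound 1 to compound 3 (0.05 log units; within the scatter). The number therefore shows no measurable response to this change, and bromo at this place is not required for a value in this region, as compound 3 gives 20000 nM with hydrogen there. No available evidence bears on this result.

The compounds shown compare only bromo and hydrogen at this place, so it remains open whether a different group there, such as an amine, a carboxylic acid or a longer alkyl chain, would move the number beyond the scatter. Going by these compounds alone, also open is what the fluoro groups on the two side arms contribute, as compound 2 differs from compound 1 and compound 3 in more than one place and gives no single-place step.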